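Fluoro to chloro on the fused ring of the core

This account rests on a few compounds, and the source may have more. Where it says the series, first, only, none or still open, it means among the compounds named here.

The series shares one core. Compound 1 `O=c1c2ccccc2ccn1[C@@H]1O[C@H](COP(=O)(O)OP(=O)(O)OP(=O)(O)O)[C@@H](O)[C@H]1O` carries hydrogen at the position under study and compound 2 `O=c1c2cc(F)ccc2ccn1[C@@H]1O[C@H](COP(=O)(O)OP(=O)(O)OP(=O)(O)O)[C@@H](O)[C@H]1O` carries fluoro there. In a functional assay for agonist activity at P2Y purinoceptor 4 (Homo sapiens), read by FLIPR (on this read-out higher numbers stand for an effect only at larger amounts of compound and lower numbers for an effect already at smaller amounts), compound 1 gives 7040 nM, and in this assay compound 2 gives 3580 nM. The step of a 2.0-fold lower number from compound 1 to compound 2 (0.29 log units; within the scatter) is within the scatter; compound 2 therefore has the smaller of the two numbers seen so far, but the two values are not distinguished by this assay.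

Compound 3 `O=c1c2cc(Cl)ccc2ccn1[C@@H]1O[C@H](COP(=O)(O)OP(=O)(O)OP(=O)(O)O)[C@@H](O)[C@H]1O` differs from compound 2 by chloro in place of fluoro on an aromatic carbon. Among the compounds with values here, the only measured step that touches this position is a 2.0-fold lower number from compound 1 to compound 2 (0.29 log units; within the scatter), which moved the number by less than the scatter when hydrogen was exchanged for fluoro. Within the data shown here, no measured pair compares two different halogens at this carbon, so the expectation rests on that single step alone. No step beyond the scatter is expected in this assay for compound 3, and the expected step is a 1.2-fold lower number from compound 2 to compound 3 (0.08 log units; within the scatter). Compound 3 is estimated at 3000 nM, with a range from 1200 nM to 7500 nM.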

Compound 3, half-maximal effective concentration: 20000 nM
The estimate for compound 3 lay 6.7-fold (0.82 log units) below the measured number, outside the stated range (above it).
By their numbers in this assay, from the lowest: compounds 2 and 1 (each within the scatter of the next); then compound 3.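

In this assay, within the data shown here, chloro in place of fluoro on this aromatic carbon gives a 5.6-fold higher number from compound 2 to compound 3 (0.75 log units; beyond the scatter), the first step at this position that lies beyond the scatter, so this carbon is not indifferent to which halogen it carries. Chloro in place of hydrogen gives a 2.8-fold higher number from compound 1 to compound 3 (0.45 log units; beyond the scatter), which sets compound 3 apart from both compound 1 and compound 2, while those two remain undistinguished; on this read-out, the chloro compound needs larger amounts for its effect than either of the others. The data at hand offer nothing that accounts for this difference between the two halogens.

Open, on these data alone, is whether the number keeps rising with bromo, or whether the jump is particular to chloro; a methyl, methoxy or amine group at the same carbon would show whether the trend belongs to halogens alone or extends to other groups. Also open is whether chloro gives a step of similar size on the other aromatic carbons of the shared core, since all three compounds shown vary at this one position.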